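Swapping the phenol for a pyridine on the shared core

The compounds below may be only part of what the source reports. "The series", "measured", "known", "first", "only" and "open" are said of these compounds alone.

Compound 3 `Cc1nc(-c2cccnc2)sc1-c1nnc(-c2ccc(O)cc2)o1` carries a 4-hydroxyphenyl on the shared core. In an ADME assay on THP-1 cells (Homo sapiens) for cytotoxicity, read by MTT assay (on this read-out higher numbers stand for lower toxicity in this test and lower numbers for higher toxicity in this test), compound 3 gives > 100 ug/mL, which is a limit of the assay and not a number. Its two neighbours stand at the same place. Compound 1 `Cc1nc(-c2cccnc2)sc1-c1nnc(-c2ccc(Br)cc2)o1` gives > 100 ug/mL in this assay, again a limit. Compound 2 `Cc1ccccc1-c1nnc(-c2sc(-c3cccnc3)nc2C)o1` gives > 100 ug/mL in this assay, also a limit. All three values sit at the limit of > 100 ug/mL in this assay, at which 3 of the 3 values shown sit, so the steps among them cannot be sized: a step that the two limits leave unreadable from compound 1 to compound 2, a step that the two limits leave unreadable from compound 1 to compound 3 and a step that the two limits leave unreadable from compound 2 to compound 3.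

Compound 4 `Cc1nc(-c2cccnc2)sc1-c1nnc(-c2ccncc2)o1` is not yet measured. It differs from compound 3 in one place: pyridin-4-yl in place of 4-hydroxyphenyl on an aromatic carbon. The three measured steps exchange the group at this same place on the shared core, and each of them left the read-out at the limit, so none of them sets a direction or a size for the present change. Compound 4 is therefore expected to stay at or near the limit as well. The step expected in this assay is a step that the limit leaves unreadable from compound 3 to compound 4. The estimate for compound 4 in this assay is 150 ug/mL, within 60 ug/mL to 400 ug/mL, with a fair chance that only a limit is reported again.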

Compound 4, half-maximal cytotoxic concentration: > 100 ug/mL
Compound 4 ended at the assay's limit; the forecaster's own chance of this, stated with the estimate: 80%; the middle value does not contradict the limit.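

In this assay compound 4 gives > 100 ug/mL as a limit of the assay and not a number. Its steps from compound 1, compound 2 and compound 3 therefore cannot be read, and all four compounds stand at one place: the limit of > 100 ug/mL in this assay, at which 4 of the 4 values shown sit. The compounds shown leave open whether any group at this place on the shared core moves the read-out away from the limit.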